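The compounds below may be only part of what the source reports. "The series", "measured", "known", "first", "only" and "open" are said of these compounds alone.

Compound 1 `CC(C)(NC(=O)c1cnc(-c2cscn2)nc1O)c1ccccc1`: 61%
Compound 2 `CC(C)(NC(=O)c1cnc(-n2cc(C(=O)O)cn2)nc1O)c1ccccc1`: 3%

In an ADME assay on the whole organism (Rattus norvegicus) for pharmacokinetics, at a dose of 2 mg/kg by the oral route (on this read-out lower numbers stand for lower oral bioavailability and higher numbers for higher oral bioavailability), compound 2 gives 3%, the lower of the two numbers. Compound 3 `CC(C)(NC(=O)c1cnc(-c2cc(C(=O)O)ccn2)nc1O)c1ccccc1` has 4-carboxypyridin-2-yl in place of 4-carboxy-1H-pyrazol-1-yl on an aromatic carbon. Within the data shown here, only one measured step bears on this, the large a number 58 percentage points lower from compound 1 to compound 2 (beyond the scatter), beyond the scatter, where 4-carboxy-1H-pyrazol-1-yl replaced 1,3-thiazol-4-yl. Among the measured compounds shown here, compound 3 keeps a carboxy group, so compound 2, at 3%, is the closer guide, though no measured compound tests this ring change. The expected step is a number 3 percentage points higher from compound 2 to compound 3 (within the scatter), none beyond the scatter. For compound 3 the estimated value is 6%, with an expected range of 1% to 20%.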

Compound 3, oral bioavailability: 5%
Estimate against measurement, compound 3: 1 percentage points above; the range from low to high includes it.
By their numbers in this assay, from the lowest: compounds 2 and 3 (each within the scatter of the next); then compound 1.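

In this assay, the step from the five-membered to the six-membered carboxy-bearing ring is a number 2 percentage points higher from compound 2 to compound 3 (within the scatter), so this ring change at this position does not separate the two compounds. Set against the thiazole, the pyridine acid shows a number 56 percentage points lower from compound 1 to compound 3 (beyond the scatter), so a second carboxy-bearing ring also stands far from compound 1. Nothing measured here explains this drop. Going by these compounds, both acids differ from compound 1 in ring and carboxy group together, so the share of each remains open. A plain pyridin-2-yl, or a methyl ester or primary amide in place of the carboxylic acid, would separate them.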